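Removing a nitro group from an inactive compound

This account rests on a few compounds, and the source may have more. Where it says the series, first, only, none or still open, it means among the compounds named here.

- compound 1 `COc1ccc(Oc2ccc([N+](=O)[O-])cc2-c2ccsc2S(=O)(=O)N2CCN(C(=S)Nc3ccc(Cl)cc3)CC2)cc1OC` gives > 50000 nM (a limit)
- compound 2 `COc1ccc(Oc2ccc([N+](=O)[O-])cc2-c2ccsc2S(=O)(=O)N2CCN(C(=S)Nc3ccc([N+](=O)[O-])cc3)CC2)cc1OC` gives > 50000 nM (a limit)
- compound 3 `COc1ccc(Oc2ccc([N+](=O)[O-])cc2-c2ccsc2S(=O)(=O)N2CCN(C(=O)Nc3ccc([N+](=O)[O-])cc3)CC2)cc1OC` gives > 50000 nM (a limit)

In a functional assay on HL-60 cells (Homo sapiens) for inhibition, read by CCK-8 assay, with a stated time of 48 h (a lower number here means a stronger inhibitor, a higher number a weaker inhibitor), compound 3 gives > 50000 nM as a limit, not a number. All three measured compounds share this result (the limit of > 50000 nM in this assay, at which 3 of the 3 values shown sit). Compound 4 (`COc1ccc(Oc2ccccc2-c2ccsc2S(=O)(=O)N2CCN(C(=O)Nc3ccc([N+](=O)[O-])cc3)CC2)cc1OC`) has hydrogen in place of nitro on an aromatic carbon, para to a 3,4-dimethoxyphenoxy group (hydrogen in place of nitro on an aromatic carbon). Three measured steps exist: a step that the two limits leave unreadable from compound 1 to compound 2, a step that the two limits leave unreadable from compound 1 to compound 3 and a step that the two limits leave unreadable from compound 2 to compound 3. None of them changes this nitro group, and none has a readable size. They therefore offer no measured size to carry over. The most likely expectation is that compound 4 stays at the same limit, and any readable value would be expected to lie lower. Compound 4 is estimated at about 40000 nM in this assay, with an expected range from 12000 nM to 80000 nM (this assay). This estimate means an expected at least 1.2-fold lower number from compound 3 to compound 4 (0.09 log units; that floor lies within the scatter) (this assay).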

Compound 4, half-maximal inhibitory concentration: > 50000 nM
Compound 4: only a limit was reported; the forecaster's own chance of this, stated with the estimate: 60%; at least 1.2-fold (0.09 log units) between middle value and limit.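

Compound 3 and compound 4 are both reported only as a limit in this assay, and the step between them, hydrogen in place of nitro, cannot be read. The compounds shown leave open what this nitro group does to inhibition: the limit of > 50000 nM in this assay, at which 4 of the 4 values shown sit.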